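The source may report more compounds than this note shows. Statements on the series, on what has been measured and on what is new or still open speak of the compounds shown alone.

Measured compounds in an ADME assay on MT4 cells (Homo sapiens) for cytotoxicity, read by MTT assay, with a stated time of 4 days; on this read-out higher numbers stand for lower toxicity in this test and lower numbers for higher toxicity in this test:
Compound 1, `CCCN(CCC)c1nc(Cc2c(F)cccc2F)cc(=O)[nH]1`, gives > 78000 nM, a limit of the assay.
Compound 2, `O=c1cc(Cc2c(F)cccc2F)nc(N2CCC3(CC2)OCCO3)[nH]1`, gives > 69000 nM, a limit of the assay.
Compound 3, `Cc1c(Cc2c(F)cccc2F)nc(N(C)C2CCCCC2)[nH]c1=O`, gives > 72000 nM, a limit of the assay.

None of the three values is a number; each is a limit. Compound 3 stands at the limit of > 72000 nM in this assay, at which 1 of the 3 values shown sits, so its place on these numbers is known only as a limit like the other two.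

Compound 4, `Cc1c(Cc2c(F)cccc2F)nc(N2CCCCCC2)[nH]c1=O`, has not yet been measured. It differs from compound 3 by azepan-1-yl in place of cyclohexyl(methyl)amino on an aromatic carbon. For the measured compounds named here, no step between measured compounds in this assay exists to guide the expectation, so no change beyond the usual scatter is expected. The expected step is a number no higher from compound 3 to compound 4 (the limit leaves the size open). Compound 4 is estimated at 72000 nM, within 36000 nM to 150000 nM, and most likely it will again be reported only as a limit.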

Compound 4, half-maximal cytotoxic concentration: > 75000 nM
Compound 4: only a limit was reported (the forecaster's own chance of this, stated with the estimate: 85%); at least 1.0-fold (0.01 log units) between middle value and limit.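

For the compounds shown here, compound 3 and compound 4 are both reported only as limits in this assay, so no step between them can be read. The compounds shown leave open at what concentration any of them turns cytotoxic, and how the four rank.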